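Swapping the acetyl of compound 3 for hydrogen

The compounds below may be only part of what the source reports. "The series", "measured", "known", "first", "only" and "open" are said of these compounds alone.

For the measured compounds named here, in a functional assay on P388 cells (Mus musculus) for inhibition (on this read-out higher numbers stand for weaker inhibition and lower numbers for stronger inhibition), compound 3 `COc1cc(/C=C\c2cn(C(C)=O)c3ccccc23)cc(OC)c1OC` gives 2850 nM as the only true number so far. Compound 1 `O=S(=O)(c1ccccc1)n1ccc2cc(/C=C\c3ccc4ccccc4c3)ccc21` reads > 5000 nM and that is a limit, not a number. Compound 2 `COc1cc(/C=C/c2cn(C(C)=O)c3ccccc23)cc(OC)c1OC` reads > 5000 nM and that too is a limit. Going by the values given here, the single measured step is an at least 1.7-fold lower number from compound 2 to compound 3 (0.24 log units; that floor lies within the scatter) and it comes with the fact that compounds 2 and 3 differ only in the configuration as drawn alone. Compound 4 `COc1cc(/C=C\c2c[nH]c3ccccc23)cc(OC)c1OC` has hydrogen in place of acetyl on an aromatic nitrogen instead. Among the compounds with values here, no measured step touches that acetyl, so the only anchor is compound 3 at 2850 nM and no direction can be argued. The expected change is a 1.1-fold lower number from compound 3 to compound 4 (0.06 log units; within the scatter) and no larger than the scatter. In this assay compound 4 is estimated at 2500 nM with a likely range from 900 nM to 5000 nM for the coming measurement.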

Compound 4, half-maximal inhibitory concentration: 3230 nM
Compound 4: the middle estimate sits 1.3-fold (0.11 log units) below what was measured, and the stated range covers the measured number.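

In this assay, for the compounds shown here, the one measured change at this aromatic nitrogen is a 1.1-fold higher number from compound 3 to compound 4 (0.05 log units; within the scatter). Acetyl and hydrogen therefore cannot be told apart on this read-out at this position, at least with the double bond drawn Z. The earlier step could not show this, because it concerned something else: the fact that compounds 2 and 3 differ only in the configuration as drawn

Going by these compounds, whether a different group on this nitrogen, such as a methyl or a chain ending in an amine, would separate itself from these two remains open. So does whether acetyl and hydrogen also match with the double bond drawn E.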